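Adding Chlorine to a Phenyl Ring on a Smaller Core

The source may hold more compounds than are shown below. What is called first, only, known or untested is meant among the compounds shown, and "the series" means these compounds.

Compound 1 `N#Cc1c(-c2nnc(-c3nn(-c4ccccc4)c(-c4ccccc4)c3C#N)c3nn(-c4ccccc4)cc23)nn(-c2ccccc2)c1-c1ccccc1` and compound 2 `N#Cc1c(-c2nnc(-c3nn(-c4ccccc4)c(-c4ccccc4)c3C#N)c3nn(-c4ccc(Cl)cc4)cc23)nn(-c2ccccc2)c1-c1ccccc1` share one core, while compound 3 `N#Cc1c(-c2nnc(-c3ccccc3)c3nn(-c4ccccc4)cc23)nn(-c2ccccc2)c1-c1ccccc1` and compound 4 `N#Cc1c(-c2nnc(-c3ccccc3)c3nn(-c4ccc(Cl)cc4)cc23)nn(-c2ccccc2)c1-c1ccccc1` share another; the difference between the two cores is not broken down here. In a functional assay on SK-OV-3 cells (Homo sapiens) for inhibition, read by sulforhodamine B assay, with a stated time of 48 h (on this read-out higher numbers stand for weaker inhibition of growth and lower numbers for stronger inhibition of growth), compound 1 gives 5720 nM. Compound 2 gives 36800 nM, a step of a 6.4-fold higher number from compound 1 to compound 2 (0.81 log units; beyond the scatter) that accompanies (chloro in place of hydrogen on an aromatic carbon). On the smaller core, compound 3 gives 32800 nM. Compound 4 carries the same change, (chloro in place of hydrogen on an aromatic carbon), at the same place. Resting on a 6.4-fold higher number from compound 1 to compound 2 (0.81 log units; beyond the scatter), the expected step is a 3.7-fold higher number from compound 3 to compound 4 (0.56 log units; beyond the scatter), with the caution that compound 3 already sits high and such a test can return only a limit. Compound 4 is therefore expected to give 120000 nM, within a range from 40000 nM to 350000 nM.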

Compound 4, concentration for 50% growth inhibition: > 100000 nM
Compound 4: a limit, no number; the forecaster's own chance of this, stated with the estimate: 40%; the middle value lies beyond the limit too.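

On the smaller core, the change from phenyl to 4-chlorophenyl gives an at least 3.0-fold higher number from compound 3 to compound 4 (0.48 log units; beyond the scatter) in this assay, which is weaker growth inhibition, the same direction as on the larger core. As far as these compounds go, compound 4 gives > 100000 nM, which is a limit and not a number, so the true size of the step on this core stays unknown and the two steps cannot be called equal or different: the same change on two cores in this assay, a 6.4-fold higher number (0.81 log units; beyond the scatter) from compound 1 to compound 2 and an at least 3.0-fold higher number (0.48 log units; beyond the scatter) from compound 3 to compound 4; the limit leaves it open whether they differ. The direction therefore carries over between these two cores, but this pair of cores does not establish a rule for the whole series.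

The compounds shown leave open how other groups at the same place, such as a methoxy group or an amine, would behave. They also leave open whether fluoro would follow chloro.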